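The compounds below may be only part of what the source reports. "The series", "measured", "known", "first", "only" and "open" are said of these compounds alone.

In a functional assay on Huh-7 cells (Homo sapiens) for cytotoxicity, read by CCK-8 assay, with a stated time of 72 h; a higher number here means a weaker inhibitor, a lower number a stronger inhibitor:
- compound 1, `C=CCn1c(=O)/c(=C\c2cccc(F)c2)[nH]c(=O)/c1=C\c1ccccc1OC`: 27200 nM
- compound 2, `C=CCn1c(=O)/c(=C\c2ccccc2OC)[nH]c(=O)/c1=C\c1ccccc1OC`: 21200 nM
- compound 3, `C=CCn1c(=O)/c(=C\c2ccc(F)c(Br)c2)[nH]c(=O)/c1=C\c1ccccc1OC`: "not active" (no number reported), a result without a number

Among the two numbers, compound 1 has the higher one, and compound 2 sits within the scatter of it, since a 1.3-fold lower number from compound 1 to compound 2 (0.11 log units; within the scatter). Compound 4, `C=CCn1c(=O)/c(=C\c2ccc(C)cc2)[nH]c(=O)/c1=C\c1ccccc1OC`, has not yet been measured in this assay; it differs from compound 1 in one place: 4-methylphenyl in place of 3-fluorophenyl on a double-bonded chain carbon bound to an aromatic carbon. Among the measured compounds shown here, no measured step exchanges the 3-fluorophenyl for a 4-methylphenyl, so only the change from compound 1 to compound 2 gives a feel for swapping this ring, and that step was within the scatter. Compound 4 is therefore expected to stay near compound 1, with a 1.1-fold higher number from compound 1 to compound 4 (0.04 log units; within the scatter). The estimate for compound 4 is 30000 nM, with a range from 12000 nM to 80000 nM.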

Compound 4, half-maximal inhibitory concentration: "not active" (no number reported)
No number was reported for compound 4, so the estimate cannot be set against anything.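

Among the compounds shown here, compound 4 is reported as "not active" in this assay with no number, so no step from compound 1 to compound 4 can be read, and no measured evidence bears on this result. The compounds shown leave open how much 4-methylphenyl in place of 3-fluorophenyl changes the number.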